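A few compounds are considered here, and "the series" means these few. Any claim that something is new, unique, unknown or untested is made for them only; others in the source may bear on it.

Two compounds of this series have numbers in hand. Compound 1 `O=C(NC(=S)Nc1ccc(Cl)c(-c2nc3ccccc3[nH]2)c1)c1ccc(OCc2ccc(C(F)(F)F)cc2)cc1` gives 12900 nM in a functional assay on HT-29 cells (Homo sapiens) for inhibition, read by MTT assay, with a stated time of 48 h; on this read-out higher numbers stand for weaker inhibition and lower numbers for stronger inhibition. Compound 2 `Cc1ccc(NC(=O)NC(=O)c2ccc(OCc3ccccc3)cc2)cc1-c1nc2ccccc2[nH]1` gives 16400 nM in this assay; this is the higher of the two numbers, yet the gap to compound 1 lies within the scatter, so no order between them is claimed. Compound 3 `Cc1ccc(NC(=O)NC(=O)c2ccc(OCc3cccc(Cl)c3)cc2)cc1-c1nc2ccccc2[nH]1` is not yet measured; it differs from compound 2 by chloro in place of hydrogen on an aromatic carbon. Within the data shown here, no measured pair shows this change, so the expected step is small, in no set direction, and within the scatter: a 1.2-fold lower number from compound 2 to compound 3 (0.07 log units; within the scatter) is the estimated shift. For compound 3 the expected value is 14000 nM, with a range from 6000 nM to 32000 nM.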

Compound 3, half-maximal inhibitory concentration: 15400 nM
Compound 3: the middle estimate sits 1.1-fold (0.04 log units) below what was measured; low and high end bracket the measured number.
By their numbers in this assay, from the lowest: compounds 1, 3 and 2 (each within the scatter of the next).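

Among these compounds, the pair compound 2 and compound 3 gives the first direct reading of chloro in place of hydrogen on this ring: in this assay the step is a 1.1-fold lower number from compound 2 to compound 3 (0.03 log units; within the scatter) and so shows no readable effect of going from benzyloxy to (3-chlorobenzyl)oxy. At this position, a single chlorine is thus tolerated on this read-out. No outside data on this result are at hand.

From the compounds shown here alone, whether an amine or a carboxylic acid at this position would move the number remains open. So does the effect of chloro elsewhere on this ring.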